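Fluoro on the distal ring of biphenyl salicylic acids

A few compounds are considered here, and "the series" means these few. Any claim that something is new, unique, unknown or untested is made for them only; others in the source may bear on it.

Three compounds have been run in a functional assay on the whole organism with Rattus norvegicus as the target; on this read-out lower numbers stand for an effect already at smaller amounts and higher numbers for an effect only at larger amounts of compound. Compound 1 `O=C(O)c1cc(-c2ccccc2)ccc1O` gives 54 mg/kg. Compound 2 `O=C(O)c1ccc(-c2ccccc2)cc1O`, built from the same atoms joined differently, gives 150 mg/kg; the difference between the two cores is not broken down here. Compound 3 `O=C(O)c1cc(-c2ccccc2F)ccc1O` gives 20 mg/kg, and the change fluoro in place of hydrogen on an aromatic carbon made a 2.7-fold lower number from compound 1 to compound 3 (0.43 log units; beyond the scatter).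

Compound 4 `O=C(O)c1ccc(-c2ccc(F)cc2)cc1O` is not yet measured. It carries the change (fluoro in place of hydrogen on an aromatic carbon), the same kind of change as before, though here the fluoro sits para to a large group rather than ortho to it. Set beside the earlier step, compound 4 is expected to show a 2.0-fold lower number from compound 2 to compound 4 (0.30 log units; within the scatter), because compound 2 starts from 150 mg/kg and the one comparable step is a 2.7-fold lower number from compound 1 to compound 3 (0.43 log units; beyond the scatter). The estimate for compound 4 is 75 mg/kg, with a range from 30 mg/kg to 200 mg/kg.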

Compound 4, dose for half-maximal effect: 400 mg/kg
Beside the measured number, compound 4's estimate is 5.3-fold (0.73 log units) below it, and the stated range ends below it.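

Fluoro in place of hydrogen on an aromatic carbon does not carry over between these two cores in this assay: on the core of compound 2 it gives a 2.7-fold higher number from compound 2 to compound 4 (0.43 log units; beyond the scatter) and so runs against the earlier step on the core of compound 1. The two steps differ in direction and lie clearly apart: the same change on two cores in this assay, a 2.7-fold lower number (0.43 log units; beyond the scatter) from compound 1 to compound 3 and a 2.7-fold higher number (0.43 log units; beyond the scatter) from compound 2 to compound 4, 7.2-fold (0.86 log units) apart, beyond the scatter of two such steps. What this does not show is whether the core or the place of the fluoro sets the outcome, since compound 4 carries it para to a large group and compound 3 carries it elsewhere, so both differ at once.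

Still open, as far as these compounds go, is how fluoro para to a large group behaves on the core of compound 1. Also open, from the compounds shown here alone, is whether a chloro or methoxy group in the same place would follow fluoro on either core.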